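From 4-Chlorophenyl to 2-Chloropyridin-4-yl on a Shared Core

The compounds below may be only part of what the source reports. "The series", "measured", "known", "first", "only" and "open" are said of these compounds alone.

Compound 1, `Cc1ncc([N+](=O)[O-])n1CCSc1nnc(-c2ccccc2N)o1`: in a functional assay on MCF7 cells (Homo sapiens) for cytotoxicity, read by MTT assay, with a stated time of 48 h (on this read-out higher numbers stand for weaker inhibition and lower numbers for stronger inhibition), compound 1 gives 20100 nM.
Compound 2, `Cc1ncc([N+](=O)[O-])n1CCSc1nnc(-c2ccc(N)cc2)o1`: in this assay compound 2 gives 19800 nM.
Compound 3, `Cc1ncc([N+](=O)[O-])n1CCSc1nnc(-c2ccc(Cl)cc2)o1`: in this assay compound 3 gives 18700 nM.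

Compound 3 has the lowest of the three numbers, but the steps of a 1.1-fold lower number from compound 1 to compound 3 (0.03 log units; within the scatter) and a 1.1-fold lower number from compound 2 to compound 3 (0.02 log units; within the scatter) both sit within the scatter, so no order among the three can be read. Compound 4, `Cc1ncc([N+](=O)[O-])n1CCSc1nnc(-c2ccnc(Cl)c2)o1`, differs from compound 3 by 2-chloropyridin-4-yl in place of 4-chlorophenyl on an aromatic carbon. The measured steps that bear on this ring change, a 1.0-fold lower number from compound 1 to compound 2 (0.01 log units; within the scatter), a 1.1-fold lower number from compound 1 to compound 3 (0.03 log units; within the scatter) and a 1.1-fold lower number from compound 2 to compound 3 (0.02 log units; within the scatter), all fall within the scatter, so the shared core is not seen to respond to a change of this group. Compound 4 is therefore expected near compound 3, with an estimated step of a 1.0-fold higher number from compound 3 to compound 4 (0.01 log units; within the scatter) in this assay. The estimate for compound 4 is 19000 nM, within 9000 nM to 40000 nM.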

Compound 4, half-maximal inhibitory concentration: 40500 nM
Estimate against measurement, compound 4: 2.1-fold (0.33 log units) below; measured number above the stated range.
By their numbers in this assay, from the lowest: compounds 3, 2, 1 and 4 (each within the scatter of the next, the first and the last beyond it).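

The position on the five-membered aromatic ring, silent among compound 1, compound 2 and compound 3, now shows a modest response in this assay: 2-chloropyridin-4-yl in place of 4-chlorophenyl gives a 2.2-fold higher number from compound 3 to compound 4 (0.34 log units; beyond the scatter), and in place of 4-aminophenyl gives a 2.0-fold higher number from compound 2 to compound 4 (0.31 log units; beyond the scatter). In place of 2-aminophenyl, the step stays within the scatter, at a 2.0-fold higher number from compound 1 to compound 4 (0.30 log units; within the scatter). Nothing available accounts for these steps. Going by these compounds, whether an unsubstituted pyridin-4-yl, or a 2-chloropyridin-3-yl, would give the same number stays open, as does the effect of an amine or a carboxylic acid on the pyridine ring.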